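The compounds below may be only part of what the source reports. "The series", "measured", "known", "first", "only" and "open" are said of these compounds alone.

Working notes on the series.

Compound 1 `COC(=O)[C@@]1(C)CCC=C2[C@@H]1CC[C@@H](C)[C@]2(C)Cc1c(C)[nH]c2ccc(C)cc12` and compound 2 `COC(=O)[C@@]1(C)CCC=C2[C@@H]1CC[C@@H](C)[C@]2(C)Cc1c(C)[nH]c2ccc(Br)cc12` share one core; in a functional assay on T47D cells (Homo sapiens) for inhibition, read by sulforhodamine B assay, with a stated time of 48 h (a lower number here means a stronger inhibitor of growth, a higher number a weaker inhibitor of growth), compound 1 gives 31000 nM, and compound 2 gives 16000 nM. The step between them is bromo in place of methyl on an aromatic carbon, and it gave a 1.9-fold lower number from compound 1 to compound 2 (0.29 log units; within the scatter).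

Compound 3 `COC(=O)[C@@]1(C)CC[C@@H]2C3=C1CC[C@@H](C)[C@]3(C)C[C@@H]1c3cccc(C)c3N[C@H]21` has a different core; the difference between the two cores is not broken down here. In this assay compound 3 gives 29000 nM, which sits within the scatter of both compound 1 and compound 2.

Compound 4 `COC(=O)[C@@]1(C)CC[C@@H]2C3=C1CC[C@@H](C)[C@]3(C)C[C@@H]1c3cccc(Br)c3N[C@H]21` is not yet measured. It differs from compound 3 by bromo in place of methyl on an aromatic carbon. This is the same kind of change as that from compound 1 to compound 2, though not the same: in compound 4 the bromo sits on a ring that is part of a fused or bridged system of five rings, ortho to a fused ring and meta to a fused ring, whereas in compound 2 the ring belongs to a fused or bridged system of two rings and the bromo is meta to a fused ring and para to a fused ring.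

For the measured compounds named here, the expectation for compound 4 rests on the one earlier step, a 1.9-fold lower number from compound 1 to compound 2 (0.29 log units; within the scatter), which was itself within the scatter, so a step of a 1.8-fold lower number from compound 3 to compound 4 (0.26 log units; within the scatter) is estimated, with the caution that this rests on a single pair. Compound 4 is expected to give 16000 nM in this assay, with a likely range from 7000 nM to 40000 nM.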

Compound 4, concentration for 50% growth inhibition: 37000 nM
Beside the measured number, compound 4's estimate is 2.3-fold (0.36 log units) below it; measured number inside the range.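

In this assay, bromo in place of methyl on an aromatic carbon gives a 1.3-fold higher number from compound 3 to compound 4 (0.11 log units; within the scatter). Set beside the earlier step, the change cannot be told apart between the two cores: the same change on two cores in this assay, a 1.9-fold lower number (0.29 log units; within the scatter) from compound 1 to compound 2 and a 1.3-fold higher number (0.11 log units; within the scatter) from compound 3 to compound 4, 2.5-fold (0.39 log units) apart, within the scatter of two such steps. This gives no sign that the core alters the effect of the change, but it does not show that the change carries over intact: each core offers a single pair and neither step is beyond the scatter, so no size or direction for the change is established on either core.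

The compounds shown leave open whether any group on the aromatic ring can move the number beyond the scatter in this assay, as only methyl and bromo appear there, and a methoxy group or an amine would be further cases. Also open, on these data alone, is the part played by the methyl ester that all four compounds share, for which a carboxylic acid or an amide would be the direct comparison.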